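Thiophene in place of dimethylaminophenyl: an expectation

The source may hold more compounds than are shown below. What is called first, only, known or untested is meant among the compounds shown, and "the series" means these compounds.

Measured compounds:
Compound 1, `CC1(C)OC(=O)C2(C(=O)O1)C(c1ccc(Cl)cc1)C(c1ccccc1)=NN2c1ccccc1`, 590000 nM
Compound 2, `CN(C)c1ccc(C2C(c3ccccc3)=NN(c3cccc(Cl)c3)C23C(=O)OC(C)(C)OC3=O)cc1`, 430000 nM

Both compounds were examined in a functional assay on aorta (Rattus norvegicus, strain Wistar) for inhibition; a lower number here means a stronger inhibitor, a higher number a weaker inhibitor. In this assay compound 1 gives 590000 nM, and compound 2 gives 430000 nM. Compound 2 holds the lower of the two numbers, but its gap to compound 1 lies within the scatter, so the two compounds cannot be separated on these data. The two also differ from each other at more than one place, so no single change can be read from them.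

Compound 3, `CC1(C)OC(=O)C2(C(=O)O1)C(c1cccs1)C(c1ccccc1)=NN2c1cccc(Cl)c1`, differs from compound 2 in one place: thiophen-2-yl in place of 4-(dimethylamino)phenyl on a saturated ring carbon. Among the compounds with values here, no pair of measured compounds tracks this kind of exchange, so the size of the step from compound 2 to compound 3 in this assay has no precedent here. Both measured numbers are very high, and nothing among them points in a direction. The working expectation is therefore a step no larger than the scatter, a 1.0-fold higher number from compound 2 to compound 3 (0.02 log units; within the scatter), with wide uncertainty. Compound 3 is estimated at 450000 nM, within a range from 150000 nM to 1400000 nM.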

Compound 3, half-maximal inhibitory concentration: 321000 nM
Compound 3: middle estimate off by 1.4-fold (0.15 log units), on the high side; measured number inside the range.
By their numbers in this assay, from the lowest: compounds 3, 2 and 1 (each within the scatter of the next).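

In this assay, within the data shown here, thiophen-2-yl in place of 4-(dimethylamino)phenyl on the saturated ring carbon gives a 1.3-fold lower number from compound 2 to compound 3 (0.13 log units; within the scatter), the first comparison at this position in which only one place differs. The group that leaves has 9 heavy atoms and a six-membered aromatic ring of carbon only, while the group that enters has 5 heavy atoms and a five-membered aromatic ring with 1 hetero atom, yet this exchange leaves the two compounds inseparable in this assay. No independent measurement is available to explain this result.

The compounds shown leave open whether a group without an aromatic ring at this position, such as cyclohexyl, a longer alkyl chain or a carboxylic acid, would produce a step beyond the scatter. They also leave open whether an exchange elsewhere, such as an amine in place of the chlorine of the 3-chlorophenyl group, would shift the number from the level of compound 3, at 321000 nM.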